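The source may hold more compounds than are shown below. What is called first, only, known or untested is meant among the compounds shown, and "the series" means these compounds.

Within the data shown here, the three compounds measured so far sit close together in an assay on cells for antagonist activity at D(4) dopamine receptor (Homo sapiens), read by luminescence and beta-arrestin recruitment, with a stated time of 90 min; on this read-out higher numbers stand for weaker inhibition and lower numbers for stronger inhibition. Compound 1 `Cc1ccc(C2CCN(CC(=O)Nc3cccc(C)c3)CC2)cc1` gives 7350 nM in this assay. Compound 2 `CCc1cccc(NC(=O)CN2CCN(c3ccc(Cl)cn3)CC2)c1` gives 10400 nM in this assay, and compound 3 `Cc1cccc(NC(=O)CCN2CCC(c3ccccn3)CC2)c1` gives 3810 nM in this assay. Compound 1 stands second highest of these three numbers, with compound 2 as its nearest neighbour and compound 3 as its furthest, and both of those gaps fall within the usual scatter of repeated measurements, so none of the three can be set apart from the others.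

Compound 4 `Cc1cccc(NC(=O)CN2CCC(c3ccc(Cl)cc3)CC2)c1` has not yet been measured. It differs from compound 1 in one place: chloro in place of methyl on an aromatic carbon. Among the measured compounds shown here, no measured pair shows what this exchange does here, so the expected step from compound 1 to compound 4 in this assay, a 1.2-fold lower number from compound 1 to compound 4 (0.09 log units; within the scatter), is small and not clearly beyond the scatter in either direction. The estimate for compound 4 in this assay is 6000 nM, with a range from 2500 nM to 15000 nM.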

Compound 4, half-maximal inhibitory concentration: 42400 nM
Compound 4: middle estimate off by 7.1-fold (0.85 log units), on the low side, outside the stated range (above it).
By their numbers in this assay, from the lowest: compounds 3, 1 and 2 (each within the scatter of the next, the first and the last beyond it); then compound 4.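

In this assay, the exchange of methyl for chloro on an aromatic carbon, para to a large group, gives a 5.8-fold higher number from compound 1 to compound 4 (0.76 log units; beyond the scatter), the first single-place change available here and one that lies beyond the scatter. This shows that the position is not indifferent to what it carries: replacing one heavy atom with another, with no change in the counted hydrogen-bond donors, hydrogen-bond acceptors or net charge, is enough to weaken inhibition. Nothing available here bears on why the exchange has this effect.

On these data alone, it remains open whether the weakening is particular to chloro or would also appear with fluoro, methoxy or an amine at this position. The compounds shown also leave open whether the same exchange would have a similar effect on a different core.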